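A few compounds are considered here, and "the series" means these few. Any claim that something is new, unique, unknown or untested is made for them only; others in the source may bear on it.

Measured so far in a functional assay for inhibition of sodium/hydrogen exchanger (Oryctolagus cuniculus); a higher number here means a weaker inhibitor, a lower number a stronger inhibitor:
compound 1 `CCc1cc(Cl)c(S(C)(=O)=O)cc1C(=O)N=C(N)N`, 63 nM
compound 2 `Cc1c(C(=O)N=C(N)N)cc(S(C)(=O)=O)c(Cl)c1[N+](=O)[O-]`, 44 nM
compound 3 `Cc1cc(-c2ccco2)c(S(C)(=O)=O)cc1C(=O)N=C(N)N`, 16 nM

Compound 3 holds the lowest number of the three. Its nearest neighbour is compound 2, whose number is higher by more than the scatter, and the gap to compound 1 is wider still; on these numbers compound 3 is the strongest inhibitor of the set. For the measured compounds named here, the three differ in more than one place, so no single step between them can be read off.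

Compound 4 `Cc1cc(Oc2cccc(Cl)c2)c(S(C)(=O)=O)cc1C(=O)N=C(N)N` is not yet measured. It differs from compound 3 at one site: 3-chlorophenoxy in place of furan-2-yl on an aromatic carbon. The group that enters is larger than the one that leaves and its ring is six-membered and of carbon only; the ring oxygen of the furan-2-yl is exchanged for the ether oxygen of the 3-chlorophenoxy, so the count of hydrogen-bond acceptors is unchanged.

Nothing measured here shows how this assay answers an aryloxy group in this place. The expectation is a modest loss, of a size a little beyond the scatter, rather than a gain: the step from compound 3 to compound 4 is expected to be a 1.9-fold higher number from compound 3 to compound 4 (0.27 log units; within the scatter). Compound 4 is therefore estimated at 30 nM, within a range of 10 nM to 100 nM.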

Compound 4, half-maximal inhibitory concentration: 21 nM
Beside the measured number, compound 4's estimate is 1.4-fold (0.15 log units) above it; the range from low to high includes it.
By their numbers in this assay, from the lowest: compounds 3 and 4 (each within the scatter of the next); then compounds 2 and 1 (each within the scatter of the next).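

In this assay the exchange of furan-2-yl for 3-chlorophenoxy gives a 1.3-fold higher number from compound 3 to compound 4 (0.12 log units; within the scatter) and so leaves no difference that can be read between the two groups on this aromatic carbon, ortho to a methylsulfonyl group. For the compounds shown here, this is the first single-site comparison, and it shows that a five-membered aromatic ring joined directly to this carbon and a chlorinated six-membered aromatic ring of carbon only, joined through an ether oxygen, give values within the scatter of each other, even though the entering group has more heavy atoms. Nothing available explains why the two groups give such similar values.

Because the ring, the ether oxygen and the chlorine all change in this single exchange, the pair cannot show what each contributes, and a plain phenoxy group or a phenyl group joined directly to the same carbon would be needed to separate them. The compounds shown also leave open how this position answers an amine such as piperidine or a carboxylic acid, neither of which resembles the aromatic groups compared here.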